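Swapping Bromo for Chloro on the Pendant Aryl Ring

The source may hold more compounds than are shown below. What is called first, only, known or untested is meant among the compounds shown, and "the series" means these compounds.

compound 1 `COc1ccc(C2=NN(c3nc(-c4ccc(Br)cc4)cs3)C(c3cccs3)C2)cc1` — 21200 nM
compound 2 `Brc1ccc(C2=NN(c3nc(-c4ccc(Br)cc4)cs3)C(c3cccs3)C2)cc1` — 28300 nM

In a functional assay on MCF7 cells (Homo sapiens) for antiproliferative activity, read by MTT assay, with a stated time of 48 h (on this read-out higher numbers stand for weaker inhibition and lower numbers for stronger inhibition), compound 1 gives 21200 nM, and compound 2 gives 28300 nM. Within the data shown here, compound 2 thus stands at one of two numbers that sit within the scatter of each other, and the single step that connects them, a 1.3-fold higher number from compound 1 to compound 2 (0.13 log units; within the scatter), does not separate the two compounds.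

Compound 3 `Clc1ccc(C2=NN(c3nc(-c4ccc(Br)cc4)cs3)C(c3cccs3)C2)cc1` differs from compound 2 by chloro in place of bromo on an aromatic carbon. Among the measured compounds shown here, the only measured step that bears on this, a 1.3-fold higher number from compound 1 to compound 2 (0.13 log units; within the scatter), was itself an exchange of one substituent for another at the same place and left the number within the scatter. The present change is again such an exchange, so no step beyond the scatter is expected in this assay. The expected step is a 1.1-fold lower number from compound 2 to compound 3 (0.05 log units; within the scatter). Compound 3 is therefore estimated at 25000 nM, within a range from 12000 nM to 50000 nM.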

Compound 3, half-maximal inhibitory concentration: 14700 nM
Compound 3: the middle estimate sits 1.7-fold (0.23 log units) above what was measured, within the range that was stated.
By their numbers in this assay, from the lowest: compounds 3, 1 and 2 (each within the scatter of the next).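

In this assay, the exchange of bromo for chloro on the aromatic carbon para to a large group gives a 1.9-fold lower number from compound 2 to compound 3 (0.28 log units; within the scatter) and does not separate the two compounds. The comparison with the methoxy compound gives a 1.4-fold lower number from compound 1 to compound 3 (0.16 log units; within the scatter), so chloro, bromo and methoxy at this place all lie within the scatter of one another, and this position has not yet yielded a step that can be read as a real difference. No measurement on hand bears on this result.

From the compounds shown here alone, whether an amine or a carboxylic acid at this place would give a step beyond the scatter remains open. So does whether changes elsewhere on the shared core would move the number more than these exchanges have.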